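The source may report more compounds than this note shows. Statements on the series, on what has been measured and on what is new or still open speak of the compounds shown alone.

Measured so far:
Compound 1 `COc1cc(C(=O)N2CCCC2)ccc1-c1ccnc2[nH]c(C3CCOCC3)cc12` gives 74 uL/min in an ADME assay on microsomes from liver (Homo sapiens) for metabolic stability; on this read-out lower numbers stand for slow clearance and higher numbers for fast clearance.
Compound 2 `COc1cc(C(=O)N2CCCC2)ccc1-c1ccnc2[nH]c(C3CCNCC3)cc12` gives < 3 uL/min in this assay, which is a limit of the assay and not a number.

Compound 1 stands as the only number shown; the other value is a limit. Going by the values given here, the one measured step, an at least 24-fold lower number from compound 1 to compound 2 (1.39 log units; beyond the scatter), arose from piperidin-4-yl in place of oxan-4-yl on an aromatic carbon, and the low end of that step sits at the limit of < 3 uL/min in this assay, at which 1 of the 2 values shown sits. Compound 3 `COc1cc(F)ccc1-c1ccnc2[nH]c(C3CCOCC3)cc12` differs from compound 1 in another way: fluoro in place of (pyrrolidin-1-yl)carbonyl on an aromatic carbon. Among the compounds with values here, no measured step touches this position or these groups, so that step does not bear on the change, and the data give no direction for it. Compound 3 is therefore expected to stay near compound 1, with a 1.2-fold lower number from compound 1 to compound 3 (0.09 log units; within the scatter), and its value in this assay is estimated at 60 uL/min, within 20 uL/min to 160 uL/min.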

Compound 3, intrinsic clearance in a liver preparation (reported as CLH), per the amount of preparation that the assay uses: 10 uL/min
Estimate against measurement, compound 3: 6.0-fold (0.78 log units) above; the whole stated range lies above it.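

Going by these compounds alone, the result shows that the group on this aromatic carbon, meta to a methoxy group, also matters in this assay, whereas the earlier compounds showed an effect only at the oxan-4-yl group. Fluoro in place of (pyrrolidin-1-yl)carbonyl gives a 7.4-fold lower number from compound 1 to compound 3 (0.87 log units; beyond the scatter), so this change on its own moves the number by more than the usual scatter, though with the oxan-4-yl group kept. Nothing known from these compounds accounts for this step.

The compounds shown leave open whether the step follows from the loss of the carbonyl, the loss of the pyrrolidine ring or the arrival of fluoro, and a nitrile, a carboxylic acid or an open-chain dimethylamide at this place could help separate these. They also leave open how fluoro at this place behaves together with the piperidin-4-yl group.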